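Swapping the Aryl Amine Group in a Fused Bicyclic Series

The source may hold more compounds than are shown below. What is called first, only, known or untested is meant among the compounds shown, and "the series" means these compounds.

Measured so far:
compound 1 `C[C@@H]1CN(c2cccc3c2C[C@H](CN(C)[C@H]2CCCc4cccnc42)NC3)C[C@H](C)N1`: 100%
compound 2 `CN1CCN(c2cccc3c2C[C@H](CN(C)[C@H]2CCCc4cccnc42)NC3)CC1`: 75.8%

Two compounds have been examined in an ADME assay on microsomes from liver (Homo sapiens) for metabolic stability, read by LC-MS, with a stated time of 10 min; a higher number here means that more of the compound is left, a lower number that less of the compound is left. Within the data shown here, compound 1 `C[C@@H]1CN(c2cccc3c2C[C@H](CN(C)[C@H]2CCCc4cccnc42)NC3)C[C@H](C)N1` gives 100% in this assay, and compound 2 `CN1CCN(c2cccc3c2C[C@H](CN(C)[C@H]2CCCc4cccnc42)NC3)CC1` gives 75.8%, the lowest of the two numbers; its nearest neighbour is compound 1, with the one step recorded, a number 24.2 percentage points lower from compound 1 to compound 2 (beyond the scatter). Compound 3 `CN(C[C@H]1Cc2c(cccc2N2CCN3CCC[C@H]3C2)CN1)[C@H]1CCCc2cccnc21` differs from compound 2 in the same region of the shared core: a group of 9 heavy atoms (7 carbon, 2 nitrogen; one five-membered non-aromatic ring with 1 hetero atom, one six-membered non-aromatic ring with 2 hetero atoms) in place of a group of 7 heavy atoms (5 carbon, 2 nitrogen; one six-membered non-aromatic ring with 2 hetero atoms), on an aromatic carbon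

Among the measured compounds shown here, only that one measured step bears on the new change, and it shows that exchanging the group on this aromatic carbon can move the read-out in this assay by a modest amount. It offers no direction for a bicyclic replacement, so the estimate for compound 3 stays close to compound 2 and the expected step is a number 5.8 percentage points lower from compound 2 to compound 3 (within the scatter). Compound 3 is therefore expected to give about 70% in this assay, within a range from 45% to 95%.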

Compound 3, percent of the compound remaining: 36.6%
The estimate for compound 3 lay 33.4 percentage points above the measured number, and the stated range ends above it.
By their numbers in this assay, from the lowest: compound 3; then compound 2; then compound 1.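

In this assay, the result shows that this aromatic carbon, ortho to a fused ring and meta to a fused ring, can carry changes far larger than the first exchange suggested: adding a five-membered non-aromatic ring to the six-membered ring gives a number 39.2 percentage points lower from compound 2 to compound 3 (beyond the scatter), a large step where the earlier one was modest. The wider comparison gives a number 63.4 percentage points lower from compound 1 to compound 3 (beyond the scatter), and together the three groups show that the read-out does not follow heavy-atom count, since the group of compound 1 is larger than that of compound 2 yet stands higher, while the largest group, in compound 3, stands lowest. The groups leaving and entering between compound 2 and compound 3 also have the same counts of hydrogen-bond donors and acceptors, and nothing available explains the size of this step.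

The compounds shown leave open whether the fused five-membered ring itself or its defined stereocentre goes with the lower number, as the opposite stereoisomer of this group does not appear among them. They also leave open how a morpholin-4-yl or piperidin-1-yl group on the same aromatic carbon would stand in this assay.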